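A few compounds are considered here, and "the series" means these few. Any claim that something is new, unique, unknown or untested is made for them only; others in the source may bear on it.

Compound 1, `CC(c1cc2cccnc2cc1F)n1cnc2ncc(-c3cnn(C)c3)nc21`, is the starting point. Among the compounds with values here, in an ADME assay on microsomes from liver (Rattus norvegicus) for metabolic stability, read by LC-MS, using NADPH, with stated times of 5 min and 30 min, tested at 1 uM (a higher number here means faster removal of the compound, a lower number slower removal), compound 1 gives 18 uL/min, the lowest of the two numbers measured so far. Within the data shown here, its only measured neighbour is compound 2, `CC(c1c(F)cc2ncccc2c1F)n1cnc2ncc(-c3cnn(C)c3)nc21`, which in this assay gives 63 uL/min; the single recorded step, a 3.5-fold higher number from compound 1 to compound 2 (0.54 log units; beyond the scatter), came from fluoro in place of hydrogen on an aromatic carbon.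

The step now followed leads to compound 3, `COC(=O)c1ccc(-c2cnc3ncn(C(C)c4cc5cccnc5cc4F)c3n2)cc1F`, which has not yet been measured. The change from compound 1 is 3-fluoro-4-(methoxycarbonyl)phenyl in place of 1-methyl-1H-pyrazol-4-yl on an aromatic carbon. Among the measured compounds shown here, this is a different kind of alteration from the one between compound 1 and compound 2, so no measured step bears on it directly; the recorded step shows only that a small change on this core can move the number beyond the usual scatter.

With nothing comparable to lean on, a modest rise is expected rather than a fall, with wide uncertainty in both directions. For compound 3 the estimated step is a 2.2-fold higher number from compound 1 to compound 3 (0.35 log units; beyond the scatter). Compound 3 is therefore expected to give about 40 uL/min, within a range from 14 uL/min to 115 uL/min.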

Compound 3, intrinsic clearance in a liver preparation (reported as CLH), per the amount of preparation that the assay uses: 125 uL/min
The estimate for compound 3 lay 3.1-fold (0.49 log units) below the measured number; measured number outside the range, above it.
By their numbers in this assay, from the lowest: compound 1; then compounds 2 and 3 (each within the scatter of the next).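

Swapping 1-methyl-1H-pyrazol-4-yl for 3-fluoro-4-(methoxycarbonyl)phenyl on this aromatic carbon gives a 6.9-fold higher number from compound 1 to compound 3 (0.84 log units; beyond the scatter) in this assay, so the group at this position, and not only fluoro substitution in another place, can change how fast the compound is removed. The change is a large one, with a five-membered aromatic ring with 2 hetero atoms giving way to a six-membered aromatic ring of carbon only and the group growing from 6 to 11 heavy atoms, while the counts of hydrogen-bond donors and acceptors and the net charge stay the same. Several features therefore change together, and no measurement here shows which of them matters or why removal differs.

The compounds shown leave open whether the fluoro or the methoxycarbonyl group on the new ring accounts for the step, which a plain phenyl ring or a phenyl ring carrying only one of the two groups could separate. They also leave open how a carboxylic acid or an amide in place of the methyl ester would behave at this position.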